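A few compounds are considered here, and "the series" means these few. Any claim that something is new, unique, unknown or untested is made for them only; others in the source may bear on it.

Measured so far:
compound 1 `CCCCCCCCCCCCNC(=O)[C@@H](NC(=O)/C=C/c1ccccc1)[C@@H](C)O`: > 200000 nM
compound 2 `CCCCCCCCCCCCCCCCCCNC(=O)[C@@H](NC(=O)c1cc2ccccc2o1)[C@@H](C)O`: > 200000 nM
compound 3 `CCCCCCCCCCCCCCCCCCNC(=O)[C@@H](NC(=O)c1nccc2ccccc12)[C@@H](C)O`: 51200 nM

Compound 3 gives 51200 nM in a functional assay on SiHa cells (Homo sapiens) for cytotoxicity, read by MTT assay, with a stated time of 48 h (a lower number here means a stronger inhibitor, a higher number a weaker inhibitor), and is the only one of the three with a number rather than a limit. The value of compound 1 is a limit of this assay. The value of compound 2 is likewise a limit. For the measured compounds named here, the one measured step, an at least 3.9-fold lower number from compound 2 to compound 3 (0.59 log units; beyond the scatter), is bounded by the limit of > 200000 nM in this assay, at which 2 of the 3 values shown sit, and so gives only a lower bound on the change at the carbonyl carbon.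

Compound 4 `CCCCCCCCCCCCCCCCCCNC(=O)[C@@H](NC(=O)/C=C/c1ccccc1)[C@@H](C)O` is to be measured. The change from compound 3 is 2-phenylethenyl in place of isoquinolin-1-yl on a carbonyl carbon. Going by the values given here, no measured step covers this exact exchange, but compound 1 carries the same 2-phenylethenyl group on the carbonyl carbon and sits at the limit, while compound 3 with isoquinolin-1-yl gives a number. On that basis compound 4 is expected to be weaker than compound 3, the expected step being a 3.9-fold higher number from compound 3 to compound 4 (0.59 log units; beyond the scatter), most likely ending at the limit. The estimate for compound 4 in this assay is 200000 nM, with a range from 60000 nM to 600000 nM.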

Compound 4, half-maximal inhibitory concentration: 35900 nM
Estimate against measurement, compound 4: 5.6-fold (0.75 log units) above; the whole stated range lies above it.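

In this assay, 2-phenylethenyl in place of isoquinolin-1-yl on the carbonyl carbon gives a 1.4-fold lower number from compound 3 to compound 4 (0.15 log units; within the scatter) and so does not separate the two groups. For the compounds shown here, in place of 1-benzofuran-2-yl at the same carbonyl carbon it gives an at least 5.5-fold lower number from compound 2 to compound 4 (0.74 log units; beyond the scatter) while hexyl in place of hydrogen on the saturated chain gives an at least 5.5-fold lower number from compound 1 to compound 4 (0.74 log units; beyond the scatter) and this is the first sign that the chain as well as the carbonyl substituent bears on the number. Both of these steps are lower bounds only: the limit of > 200000 nM in this assay, at which 2 of the 4 values shown sit.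

From the compounds shown here alone, what a 2-phenylethyl group would give on this carbonyl carbon stays open, and with it whether the double bond matters. Also open, going by these compounds, are a chain longer than that of compound 4 and an amine or a carboxylic acid on the chain.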